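The compounds below may be only part of what the source reports. "The series", "measured", "known", "first", "only" and "open" are said of these compounds alone.

Compound 1, `CCOC(=O)[C@@H]1CCCN(S(=O)(=O)c2ccc(S(=O)(=O)N3CCNCC3)cc2)C1`: > 30000 nM
Compound 2, `CCOC(=O)[C@@H]1CCCN(S(=O)(=O)c2ccc(S(=O)(=O)N(C)Cc3ccccc3)cc2)C1`: > 30000 nM

In a functional assay on BXPC-3 cells (Homo sapiens) for inhibition, read by MTT assay, with a stated time of 7 days (a lower number here means a stronger inhibitor, a higher number a weaker inhibitor), compound 1 gives > 30000 nM, which is a limit of the assay and not a number. In this assay compound 2 gives > 30000 nM, likewise a limit and not a number. Both values sit at the limit of > 30000 nM in this assay, at which 2 of the 2 values shown sit, so replacing piperazin-1-yl with benzyl(methyl)amino on the sulfonyl sulfur yields a step that the two limits leave unreadable from compound 1 to compound 2, a step whose size cannot be read. Compound 2 therefore stands only at the limit of this assay, with nothing showing it as an inhibitor in the tested range.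

Compound 3, `CCOC(=O)[C@@H]1CCCN(S(=O)(=O)c2ccc(S(=O)(=O)N(CC)C(C)C)cc2)C1`, differs from compound 2 in one place: ethyl(isopropyl)amino in place of benzyl(methyl)amino on a sulfonyl sulfur. Going by the values given here, the only measured step at the same sulfonyl sulfur is the unreadable one from compound 1 to compound 2, so it gives no size and no direction to go on. No step beyond the scatter in this assay is expected from this change, and the likeliest outcome is that compound 3 also reaches only the limit. Compound 3 is estimated at 30000 nM, with a range from 10000 nM to 100000 nM. The expected step is a number no higher from compound 2 to compound 3 (the limit leaves the size open).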

Compound 3, half-maximal inhibitory concentration: 1600 nM
Beside the measured number, compound 3's estimate is 19-fold (1.27 log units) above it; measured number below the stated range.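

Putting ethyl(isopropyl)amino in place of benzyl(methyl)amino on the sulfonyl sulfur gives an at least 18-fold lower number from compound 2 to compound 3 (1.27 log units; beyond the scatter), so compound 3 brings the first readable activity in this assay to this series. Putting the same group in place of piperazin-1-yl gives an at least 18-fold lower number from compound 1 to compound 3 (1.27 log units; beyond the scatter), which shows that the group on this sulfur can decide whether the compounds register in the tested range at all, something the unreadable step between compound 1 and compound 2 could not show. Both new steps give only a minimum size, since compound 1 and compound 2 each stand at a limit of the assay and not at a number: the limit of > 30000 nM in this assay, at which 2 of the 3 values shown sit.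

The change from compound 2 to compound 3 removes an aromatic ring and also leaves fewer heavy atoms on the sulfur, so the compounds shown cannot tell which of these differences matters, or whether the ethyl or the isopropyl part of the new group counts more. On these data alone, it also remains open whether a simpler amine such as dimethylamino, or a ring without a second nitrogen such as piperidin-1-yl, would give a number close to that of compound 3.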